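Removing One Methoxy Group: Expected Effect on Cytotoxicity

The source may report more compounds than this note shows. Statements on the series, on what has been measured and on what is new or still open speak of the compounds shown alone.

The measured compounds and their values in a functional assay on A549 cells (Homo sapiens) for cytotoxicity, read by MTT assay, with a stated time of 72 h; on this read-out lower numbers stand for stronger inhibition and higher numbers for weaker inhibition:

compound 1, `COc1ccc(C(=O)/C=C/c2cc(OC)c(OC)c(OC)c2)c(F)c1`, 108 nM
compound 3, `COc1ccc(C(=O)/C=C/c2cc(OC)c(OC)cc2OC)c(F)c1`, 202 nM
compound 2, `COc1ccc(C(=O)/C=C/c2ccc(OC)cc2OC)c(F)c1`, for which only a limit was recorded

Compound 1 and compound 3 are built from the same atoms joined differently; the difference between the two cores is not broken down here. In this assay compound 1 gives 108 nM and compound 3 gives 202 nM, and the gap between them lies within the scatter, so no order can be read from it.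

Compound 2 reaches only a limit in this assay, namely > 100000 nM. The change that separates it from compound 3 is hydrogen in place of methoxy on an aromatic carbon, and the step it produced is an at least 490-fold higher number from compound 3 to compound 2 (2.69 log units; beyond the scatter). Here the limit of > 100000 nM in this assay, at which 1 of the 3 values shown sits, applies.

Compound 4, `COc1cc(/C=C/C(=O)c2ccc(OC)cc2F)cc(OC)c1`, is not yet measured. It arises from compound 1 through (hydrogen in place of methoxy on an aromatic carbon). Among the measured compounds shown here, this is the same kind of change as the one from compound 3 to compound 2, but the surroundings differ: in compound 1 the leaving methoxy sits ortho to two methoxy groups and para to a large group, whereas in compound 3 it sits ortho to a methoxy group, meta to a large group and para to a methoxy group.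

Given the earlier step of an at least 490-fold higher number from compound 3 to compound 2 (2.69 log units; beyond the scatter), the number for compound 4 in this assay is expected to rise sharply, by roughly a 280-fold higher number from compound 1 to compound 4 (2.44 log units; beyond the scatter). Compound 4 is therefore estimated at 30000 nM, within a range from 3000 nM to 100000 nM.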

Compound 4, half-maximal inhibitory concentration: 101 nM
For compound 4 the middle estimate is 300-fold (2.47 log units) above the measured one; measured number outside the range, below it.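

In this assay, hydrogen in place of methoxy on the core of compound 1 gave a 1.1-fold lower number from compound 1 to compound 4 (0.03 log units; within the scatter) and so left no readable change on that core. This shows that the outcome of this replacement did not carry from one core to the other in this series: a large loss on the core of compound 3 was no guide to the core of compound 1, even though the leaving group and the entering atom were the same. It does not show why the two cores part ways, and with only two such pairs, one of which ends in a limit of the assay, it gives no rule for which outcome a further core would follow; the two steps compare as follows: the same change on two cores in this assay, an at least 490-fold higher number (2.69 log units; beyond the scatter) from compound 3 to compound 2 and a 1.1-fold lower number (0.03 log units; within the scatter) from compound 1 to compound 4, at least 520-fold (2.72 log units) apart, beyond the scatter of two such steps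

The compounds shown leave open what happens on either core when the methoxy gives way to something other than hydrogen, such as a hydroxyl group, a chlorine atom or an amine. They also leave open whether the agreement between compound 1 and compound 4 would hold in any other test, since both are seen here on a single cell line and a single read-out.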